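Lengthening a Hydroxyalkyl Chain on the Amide Nitrogen

The source may report more compounds than this note shows. Statements on the series, on what has been measured and on what is new or still open speak of the compounds shown alone.

Measured compounds:
compound 1, `N=c1oc2ccc(Br)cc2cc1C(=O)NC1CCCCC1`, 8%
compound 2, `CCC(CO)NC(=O)c1cc2cccc(OC)c2oc1=N`, 6%
compound 3, `COC(=O)/C(C#N)=C/c1cccc(OC)c1O`, 45%

Of the compounds shown here, three have been tested in an assay on HeLa cells for displacement of a labelled ligand from adenosine receptor A3 (Homo sapiens), read by scintillation counting, with a stated time of 180 min, tested at 10 uM; on this read-out lower numbers stand for less inhibition and higher numbers for more inhibition at the one concentration tested (going by the name of the read-out). Compound 2 gives 6%, and compound 1 gives 8%, so these two numbers sit together within the usual scatter and neither can be placed above the other. Compound 3, built on a different core, gives 45%, a number that stands apart from both by a gap beyond the scatter. For the measured compounds named here, no step between compounds that differ in a single place has been measured, so there is no direct guide to how a small change on the shared core of compound 2 shifts the read-out.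

Compound 4, `COc1cccc2cc(C(=O)NCCCCCO)c(=N)oc12`, differs from compound 2 in one place: 5-hydroxypentyl in place of 1-(hydroxymethyl)propyl on an amide-type nitrogen. The group that leaves and the group that enters each carry one hydrogen-bond donor and one hydrogen-bond acceptor, neither has a ring or a charge, and the entering chain has one heavy atom more.

Going by the values given here, with no measured step to lean on, the expectation in this assay is a step of no size beyond the scatter in either direction, and the estimated change from compound 2 to compound 4 is a number 2 percentage points higher from compound 2 to compound 4 (within the scatter). Compound 4 is therefore estimated at 8%, with a range from 0% to 25%.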

Compound 4, a percentage reported as inhibition, at one concentration (the size of the read-out at that concentration, not a potency): 13%
Compound 4: the middle estimate sits 5 percentage points below what was measured, within the range that was stated.
By their numbers in this assay, from the lowest: compounds 2, 1 and 4 (each within the scatter of the next); then compound 3.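

In this assay, putting 5-hydroxypentyl in place of 1-(hydroxymethyl)propyl on the amide-type nitrogen gives a number 7 percentage points higher from compound 2 to compound 4 (within the scatter), and this is the only step shown between two compounds that differ in one place. It shows that this particular exchange on the nitrogen, from a group of 5 heavy atoms to one of 6, with the same count of hydrogen-bond donors and acceptors, does not move the read-out by more than ordinary repeat measurements would, so the two compounds cannot be placed in order. Nothing measured here explains the size of this step.

As far as these compounds go, a single pair says little about the position as a whole, so it remains open how the read-out would respond to a longer chain on this nitrogen, to an amine or a carboxylic acid at the end of the chain in place of the hydroxyl, or to a chain with no hydroxyl at all. From the compounds shown here alone, it is also open whether a ring on this nitrogen, such as a cyclohexyl group, would give a step beyond the scatter on the core of compound 2.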